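Methyl on the benzyl ring of compound 2

This account rests on a few compounds, and the source may have more. Where it says the series, first, only, none or still open, it means among the compounds named here.

Among the measured compounds shown here, compound 2 `O=C1NC(=S)S/C1=C\C=C\c1ccccc1OCc1ccccc1` sits second highest of the three numbers so far in an assay on isolated protein for inhibition of protein tyrosine phosphatase type IVA 3 (Homo sapiens), tested at 5 ug/mL (on this read-out higher numbers stand for more inhibition at the one concentration tested (going by the name of the read-out) and lower numbers for less inhibition), where compound 2 gives 49.5%; compound 3 `O=C1NC(=S)S/C1=C\C=C\c1ccccc1Cl` gives 53.9% and compound 1 `O=C1NC(=S)S/C1=C\C=C\c1ccccc1` gives 37.4%. The measured steps, a number 12.1 percentage points higher from compound 1 to compound 2 (beyond the scatter) and a number 16.5 percentage points higher from compound 1 to compound 3 (beyond the scatter), both alter the ring attached to the core, while a number 4.4 percentage points higher from compound 2 to compound 3 (within the scatter) lies within the scatter. For the measured compounds named here, compound 4 `Cc1ccccc1COc1ccccc1/C=C/C=C1\SC(=S)NC1=O` differs from compound 2 by methyl in place of hydrogen on an aromatic carbon, a change on the outer benzyl ring that no measured step touches. He therefore expects no step beyond the scatter in this assay, a number 2.5 percentage points higher from compound 2 to compound 4 (within the scatter), and estimates compound 4 at 52%, between 38% and 66%.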

Compound 4, a percentage reported as inhibition, at one concentration (the size of the read-out at that concentration, not a potency): 52.8%
Beside the measured number, compound 4's estimate is 0.8 percentage points below it; the range from low to high includes it.
By their numbers in this assay, from the lowest: compound 1; then compounds 2, 4 and 3 (each within the scatter of the next).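

In this assay there is a number 3.3 percentage points higher from compound 2 to compound 4 (within the scatter), so 2-methylbenzyl in place of benzyl leaves the read-out within the scatter. The earlier steps shown here changed only the ring attached to the core, whereas this one shows that the outer ring, at a carbon ortho to a large group, takes a methyl without a step beyond the scatter. Nothing available explains this result. Going by these compounds, whether an amine or a carboxylic acid at this position would give a step beyond the scatter stays open, and so does the effect of methyl elsewhere on the outer ring.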